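A few compounds are considered here, and "the series" means these few. Any claim that something is new, unique, unknown or untested is made for them only; others in the source may bear on it.

Compound 1 `Nc1nnc(SC[C@H]2O[C@@H](OCc3noc(-c4ccc(Cl)cc4)n3)[C@@H]3OC4(CCCC4)O[C@@H]32)s1` was tested in a functional assay on WiDr cells (Homo sapiens) for antiproliferative activity, read by sulforhodamine B assay, with a stated time of 48 h (a higher number here means a weaker inhibitor of growth, a lower number a stronger inhibitor of growth), where compound 1 gives 15000 nM. Among the three compounds measured, compound 1 stands second highest: compound 2 `CC(=O)OC[C@H]1O[C@@H](OCc2noc(-c3ccc([N+](=O)[O-])cc3)n2)[C@@H]2OC3(CCCC3)O[C@@H]21` gives 36000 nM, while compound 3 `Clc1ccc(-c2nc(CO[C@@H]3O[C@H](CSc4ncn[nH]4)[C@H]4OC5(CCCC5)O[C@@H]34)no2)cc1` gives 4500 nM. Among the measured compounds shown here, the only step between compounds differing in one place, a 3.3-fold lower number from compound 1 to compound 3 (0.52 log units; beyond the scatter), concerns the group on the sulfur and not the aryl ring. Compound 4 `Nc1nnc(SC[C@H]2O[C@@H](OCc3noc(-c4ccc([N+](=O)[O-])cc4)n3)[C@@H]3OC4(CCCC4)O[C@@H]32)s1` differs from compound 1 by nitro in place of chloro on an aromatic carbon. For the measured compounds named here, no measured step bears directly on this change; compound 2 also carries a nitro group but differs in a second place as well, so its number alone settles little. The step is expected to be a 1.3-fold higher number from compound 1 to compound 4 (0.12 log units; within the scatter), with no firm reason to expect a move beyond the scatter. Compound 4 is estimated at 20000 nM, within 7000 nM to 60000 nM.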

Compound 4, concentration for 50% growth inhibition: 26000 nM
The estimate for compound 4 lay 1.3-fold (0.11 log units) below the measured number, and the stated range covers the measured number.
By their numbers in this assay, from the lowest: compound 3; then compounds 1, 4 and 2 (each within the scatter of the next, the first and the last beyond it).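

Nitro in place of chloro on the six-membered aromatic ring, para to a large group, leaves the number within the scatter (a 1.7-fold higher number from compound 1 to compound 4 (0.24 log units; within the scatter)), so 4-chlorophenyl and 4-nitrophenyl cannot be told apart in (this assay). With the nitro group present, (5-amino-1,3,4-thiadiazol-2-yl)sulfanyl in place of acetoxy also stays within the scatter (a 1.4-fold lower number from compound 2 to compound 4 (0.14 log units; within the scatter)). No evidence on the cause of these results is available. Going by these compounds, whether an amine or a methoxy group at this ring position would move the number beyond the scatter remains open, as does whether 1H-1,2,4-triazol-5-yl on the sulfur would lower the number with nitro as it does with chloro.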